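The source may hold more compounds than are shown below. What is called first, only, known or untested is meant among the compounds shown, and "the series" means these compounds.

Measured so far in a functional assay on A549 cells (Homo sapiens) for antiproliferative activity, read by MTT assay, with a stated time of 48 h; a lower number here means a stronger inhibitor, a higher number a weaker inhibitor:

- compound 1 `O=C(/C=C/c1ccccc1)Nc1cc2c(Nc3ccc(F)c(Cl)c3)ncnc2s1`: 11200 nM
- compound 2 `COc1ccc(/C=C/C(=O)Nc2cc3c(Nc4cc(Cl)cc(Cl)c4)ncnc3s2)cc1`: 21900 nM
- compound 3 `O=C(/C=C/c1ccccc1)Nc1cc2c(Nc3cccc(Cl)c3F)ncnc2s1`: 26200 nM

Compound 3, at 26200 nM, lies within the usual scatter of compound 2, at 21900 nM, so these two cannot be ranked. Compound 3 is clearly weaker than compound 1, though only modestly: the gap is a 2.3-fold higher number from compound 1 to compound 3 (0.37 log units; beyond the scatter).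

The next compound to be tested is compound 4 `O=C(/C=C/c1ccccc1)Nc1cc2c(Nc3cc(Cl)cc(Cl)c3)ncnc2s1`. It has 3,5-dichlorophenyl in place of 3-chloro-2-fluorophenyl on a nitrogen on an aromatic ring.

Within the data shown here, the only measured step at this nitrogen is a 2.3-fold higher number from compound 1 to compound 3 (0.37 log units; beyond the scatter), with 3-chloro-2-fluorophenyl in place of 3-chloro-4-fluorophenyl. Swaps here have therefore moved the number only modestly so far. Compound 2 already carries 3,5-dichlorophenyl and gives 21900 nM, but it differs from compound 4 elsewhere in the molecule, so it is only a rough guide.

The expected result is a small shift, a 1.4-fold lower number from compound 3 to compound 4 (0.14 log units; within the scatter), with no change beyond the scatter anticipated. For compound 4 the estimated value is 19000 nM, with an expected range of 9000 nM to 40000 nM.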

Compound 4, half-maximal inhibitory concentration: 40 nM
Compound 4: the middle estimate sits 480-fold (2.68 log units) above what was measured, and the stated range ends above it.
By their numbers in this assay, from the lowest: compound 4; then compounds 1, 2 and 3 (each within the scatter of the next, the first and the last beyond it).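

In this assay, among these compounds, the group on this nitrogen proves able to move the number far more than the one earlier swap suggested: 3,5-dichlorophenyl in place of 3-chloro-2-fluorophenyl gives a large drop (a 660-fold lower number from compound 3 to compound 4 (2.82 log units; beyond the scatter)) and in place of 3-chloro-4-fluorophenyl another (a 280-fold lower number from compound 1 to compound 4 (2.45 log units; beyond the scatter)). The 3,5-dichlorophenyl group alone does not secure this result, since with that group kept, hydrogen in place of methoxy on an aromatic carbon gives a similarly large drop (a 550-fold lower number from compound 2 to compound 4 (2.74 log units; beyond the scatter)). Nothing available explains either jump.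

The compounds shown leave open whether the low number needs chlorine itself, or whether two bromines or two methyl groups in place of the two chlorines would retain it. They also leave open whether a smaller group than methoxy, such as fluorine or methyl, would be tolerated on that aromatic carbon.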